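This account rests on a few compounds, and the source may have more. Where it says the series, first, only, none or still open, it means among the compounds named here.

In an ADME assay for permeability, using PAMPA (a lower number here means that the compound crosses the layer more slowly, a higher number that the compound crosses the layer faster), compound 1 `CC(C)(C)CCN1C(=O)C(C2=CS(=O)(=O)c3cc(NS(C)(=O)=O)ccc3N2)=C(O)[C@@H]1C(C)(C)C` gives 1.8 10^-6 cm/s and compound 2 `CC(C)(C)[C@H]1C(O)=C(C2=CS(=O)(=O)c3cc(NS(C)(=O)=O)ccc3N2)C(=O)N1Cc1ccccc1` gives 1.8 10^-6 cm/s as well, so compound 2 stands level with compound 1. Compound 3 `CC(C)(C)[C@H]1C(O)=C(C2=CS(=O)(=O)c3cc(NS(C)(=O)=O)ccc3N2)C(=O)N1Cc1ccc(F)c(Cl)c1` carries 3-chloro-4-fluorophenyl in place of phenyl on a saturated chain carbon bound to an amide-type nitrogen in a ring. Among the compounds with values here, the only measured step at this place, neopentyl to phenyl, was no change at the digits printed from compound 1 to compound 2 (within the scatter) and gives no direction. No shift beyond the scatter is therefore expected in this assay here. An expected 1.1-fold higher number from compound 2 to compound 3 (0.05 log units; within the scatter) is the estimate. For compound 3 the estimated value is 2 10^-6 cm/s (expected range 0.9 10^-6 cm/s to 4.5 10^-6 cm/s).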

Compound 3, apparent permeability: 0.98 10^-6 cm/s
Estimate against measurement, compound 3: 2.0-fold (0.31 log units) above; the measured number falls inside the stated range.
By their numbers in this assay, from the lowest: compounds 3, 1 and 2 (each within the scatter of the next).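

In this assay, putting 3-chloro-4-fluorophenyl in place of phenyl gives a 1.8-fold lower number from compound 2 to compound 3 (0.26 log units; within the scatter) and putting it in place of neopentyl gives a 1.8-fold lower number from compound 1 to compound 3 (0.26 log units; within the scatter). At this place, on a saturated chain carbon bound to an amide-type nitrogen in a ring, all three groups shown therefore read alike within the scatter. No measurement at hand offers an explanation for these numbers. Still open, going by these compounds, is whether an amine or a carboxylic acid at this place would read differently, and whether 4-fluorophenyl alone would match these compounds.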